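The source may hold more compounds than are shown below. What is called first, only, known or untested is meant among the compounds shown, and "the series" means these compounds.

Compound 1 `NS(=O)(=O)c1ccc(Nc2nc(N/N=C/c3ccc(C(F)(F)F)cc3)nc(Nc3ccccc3)n2)cc1` gives 86600 nM in a functional assay on SN12C cells (Homo sapiens) for inhibition, read by sulforhodamine B assay, with a stated time of 48 h; a higher number here means that more compound is tolerated, a lower number that less compound is tolerated. Compound 2 `Cc1nn(-c2ccccc2)cc1/C=N/Nc1nc(Nc2ccccc2)nc(Nc2ccc(S(N)(=O)=O)cc2)n1` reaches only a limit of this assay, recorded as > 100000 nM. Between them, an at least 1.1-fold higher number from compound 1 to compound 2 (0.06 log units; that floor lies within the scatter) is known only as a floor, since the second value sits at the limit of > 100000 nM in this assay, at which 1 of the 2 values shown sits. Compound 3 `NS(=O)(=O)c1ccc(Nc2nc(N/N=C/c3ccccn3)nc(Nc3ccccc3)n2)cc1` differs from compound 2 by pyridin-2-yl in place of 3-methyl-1-phenyl-1H-pyrazol-4-yl on a carbon with a double bond to nitrogen. Within the data shown here, because the one measured change at this same place gave an at least 1.1-fold higher number from compound 1 to compound 2 (0.06 log units; that floor lies within the scatter), compound 3 is expected to stay close to both earlier values, at an estimated 90000 nM with a range from 40000 nM to 200000 nM. The expected step from compound 2 to compound 3 is therefore an at least 1.1-fold lower number from compound 2 to compound 3 (0.04 log units; that floor lies within the scatter), within the scatter.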

Compound 3, concentration lethal to 50% of the cells: > 100000 nM
Compound 3: only a limit was reported (the forecaster's own chance of this, stated with the estimate: 45%); at least 1.1-fold (0.04 log units) between middle value and limit.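

Compound 3 sits at the same limit of the assay as compound 2, so the step between these two cannot be read: the limit of > 100000 nM in this assay, at which 2 of the 3 values shown sit.

Pyridin-2-yl in place of 4-(trifluoromethyl)phenyl gives an at least 1.1-fold higher number from compound 1 to compound 3 (0.06 log units; that floor lies within the scatter). So a single ring with 1 hetero atom shows no readable departure here from either earlier group, including the larger two-ring group.

Still open, going by these compounds, is whether a quite different group on the carbon with a double bond to nitrogen, such as an amine or a carboxylic acid, would give a clearly lower number.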